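Benzylsulfanyl removal on a second dichloro core

The source may report more compounds than this note shows. Statements on the series, on what has been measured and on what is new or still open speak of the compounds shown alone.

Measured compounds in a functional assay on KB cells (Homo sapiens) for inhibition; on this read-out higher numbers stand for weaker inhibition and lower numbers for stronger inhibition:
Compound 1 `OCCOCn1c(SCc2ccccc2)nc2cc(Cl)c(Cl)cc21` gives 55000 nM.
Compound 2 `OCCOCn1cnc2cc(Cl)c(Cl)cc21` gives only a limit of the assay, > 100000 nM.
Compound 3 `OCCOCn1c(SCc2ccccc2)nc2c(Cl)c(Cl)ccc21` gives 35000 nM.

Compound 1 and compound 3 are built from the same atoms joined differently; the difference between the two cores is not broken down here. In this assay the values of compound 1 and compound 3 lie within the usual scatter of each other.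

Going by the values given here, the one measured step is hydrogen in place of benzylsulfanyl on an aromatic carbon, which gave an at least 1.8-fold higher number from compound 1 to compound 2 (0.25 log units; that floor lies within the scatter); compound 2 sits at the limit of > 100000 nM in this assay, at which 1 of the 3 values shown sits, so the true size of that step is not known.

Compound 4 `OCCOCn1cnc2c(Cl)c(Cl)ccc21` is not yet measured. It is related to compound 3 by hydrogen in place of benzylsulfanyl on an aromatic carbon, the same change as that from compound 1 to compound 2, made on the core of compound 3. Since compound 2 reached the assay limit, the step of a 2.9-fold higher number from compound 3 to compound 4 (0.46 log units; beyond the scatter) is expected to be at least as large as the measured one, with a fair chance that compound 4 also returns only a limit. In this assay compound 4 is estimated at 100000 nM, between 50000 nM and 300000 nM.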

Compound 4, half-maximal inhibitory concentration: > 100000 nM
Compound 4 ended at the assay's limit (the forecaster's own chance of this, stated with the estimate: 60%); the middle value lies on the limit itself.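

In this assay, hydrogen in place of benzylsulfanyl on the core of compound 3 gives an at least 2.8-fold higher number from compound 3 to compound 4 (0.45 log units; beyond the scatter), and that step is only a floor, since the value of compound 4 is a limit of the assay. Set beside the same change on the core of compound 1, the two steps cannot be ranked: the same change on two cores in this assay, an at least 1.8-fold higher number (0.25 log units; that floor lies within the scatter) from compound 1 to compound 2 and an at least 2.8-fold higher number (0.45 log units; beyond the scatter) from compound 3 to compound 4; the limit leaves it open whether they differ

The change therefore carries to the second core in the sense that removing benzylsulfanyl again leaves a compound at the limit, but this does not show that the size of the step is shared, and two cores do not establish a rule for the series.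

The compounds shown leave open whether the sulfur or the aromatic ring of benzylsulfanyl accounts for the step, which a methylsulfanyl group, a benzylamine or a phenethylsulfanyl chain in its place could separate. Also open, from the compounds shown here alone, is how a longer chain or a carboxylic acid in place of the (2-hydroxyethoxy)methyl group would read on either core.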